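Cytotoxicity of benzyl-imidazole anilines: compound 3 to compound 4

A few compounds are considered here, and "the series" means these few. Any claim that something is new, unique, unknown or untested is made for them only; others in the source may bear on it.

Compound 1 `COC(=O)c1ccc(NCc2cncn2Cc2ccccc2C(C)(C)C)cc1-c1ccccc1` gives "not determined" (no result reported) in a toxicity assay on NIH3T3 cells (Mus musculus) for cytotoxicity, read by resazurin assay; a lower number here means that less compound is needed, a higher number that more compound is needed for the effect.
Compound 2 `COC(=O)c1ccc(NCc2cncn2Cc2cccc(C)c2)cc1-c1ccccc1` gives > 10000 nM in this assay; this is a limit of the assay, not a number.
Compound 3 `COC(=O)c1ccc(NCc2cncn2Cc2ccc(Br)cc2)cc1-c1ccccc1` gives > 10000 nM in this assay; this again is a limit, not a number.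
Compound 4 `COC(=O)c1ccc(NCc2cncn2Cc2ccccc2C#N)cc1-c1ccccc1` is not yet measured in this assay.

Compound 3 therefore stands at the limit of this assay, and nothing shown for it is a single number. Of the other two compounds, one also sits at a limit and one carries no result at all. For the measured compounds named here, the only step between measured compounds, a step that the two limits leave unreadable from compound 2 to compound 3, is left unreadable by its two limits, so no size can be taken from it. What remains to be said is the limit of > 10000 nM in this assay, at which 2 of the 3 values shown sit, which means only that two of the three values shown rest at that limit.

The change from compound 3 to compound 4 is 2-cyanophenyl in place of 4-bromophenyl on a saturated chain carbon bound to an aromatic nitrogen. Going by the values given here, no measured step bears on this change with a readable size, and none runs in a direction that can be stated. Compound 4 is thus expected to remain at the limit of this assay, with the estimated step that the limit leaves unreadable from compound 3 to compound 4 meaning no change that can be read. For compound 4 the estimate is 15000 nM, in the range 7000 nM to 50000 nM.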

Compound 4, half-maximal effective concentration: 25000 nM
The estimate for compound 4 lay 1.7-fold (0.22 log units) below the measured number; low and high end bracket the measured number.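

Neither the step from compound 3 to compound 4 nor the step from compound 2 to compound 4 can be read in this assay, since compound 2 and compound 3 each give only a limit, not a number: the limit of > 10000 nM in this assay, at which 2 of the 4 values shown sit.

The compounds shown leave open how far the values of compound 2 and compound 3 lie from that of compound 4.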